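Nitro in place of methoxy on the aryl ketone ring

The source may hold more compounds than are shown below. What is called first, only, known or untested is meant among the compounds shown, and "the series" means these compounds.

Measured compounds in a functional assay on MDA-MB-231 cells (Homo sapiens) for antiproliferative activity, read by sulforhodamine B assay, with a stated time of 48 h; a lower number here means a stronger inhibitor, a higher number a weaker inhibitor:
- compound 1 `COc1cc(OC)c2sc(-c3ccc(N/C=C\C(=O)c4ccc(OC)c(O)c4)cc3)nc2c1`: 7610 nM
- compound 2 `COc1cc(OC)c2sc(-c3ccc(N/C=C\C(=O)c4ccc(OC)c([N+](=O)[O-])c4)cc3)nc2c1`: 12900 nM
- compound 3 `COc1cc(OC)c2sc(-c3ccc(N/C=C\C(=O)c4cc(OC)c(OC)c(OC)c4)cc3)nc2c1`: 15800 nM

Compound 3 gives the highest number of the three. Against compound 2 the gap is a 1.2-fold higher number from compound 2 to compound 3 (0.09 log units; within the scatter), against compound 1 it is a 2.1-fold higher number from compound 1 to compound 3 (0.32 log units; beyond the scatter). The next compound, compound 4 `COc1cc(OC)c2sc(-c3ccc(N/C=C\C(=O)c4cc(OC)c(OC)c([N+](=O)[O-])c4)cc3)nc2c1`, differs from compound 3 in one place: nitro in place of methoxy on an aromatic carbon.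

Among the measured compounds shown here, two measured steps bear on this change. The step of a 1.7-fold higher number from compound 1 to compound 2 (0.23 log units; within the scatter) sets a nitro on the same ring where a hydroxy stood, and stays within the scatter. The step of a 1.2-fold higher number from compound 2 to compound 3 (0.09 log units; within the scatter) likewise stays within the scatter, although it exchanges the whole aryl group on the carbonyl carbon. Compound 4 carries the 4-methoxy-3-nitro pattern of compound 2 together with the further methoxy of compound 3; neither element has moved the number beyond the scatter so far. Compound 4 is therefore expected to show a 1.1-fold lower number from compound 3 to compound 4 (0.05 log units; within the scatter), no step beyond the scatter. The estimate for compound 4 in this assay is 14000 nM, with a range from 6000 nM to 35000 nM.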

Compound 4, half-maximal inhibitory concentration: 3060 nM
Compound 4: the middle estimate sits 4.6-fold (0.66 log units) above what was measured, and the stated range ends above it.
By their numbers in this assay, from the lowest: compound 4; then compounds 1, 2 and 3 (each within the scatter of the next, the first and the last beyond it).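

In this assay, nitro in place of methoxy on this ring gives a 5.2-fold lower number from compound 3 to compound 4 (0.71 log units; beyond the scatter) and methoxy in place of hydrogen gives a 4.2-fold lower number from compound 2 to compound 4 (0.62 log units; beyond the scatter) in the two steps that reach compound 4. Among the compounds shown here, both steps lie beyond the scatter, the first such steps of this size, whereas compound 2 and compound 3 lie within the scatter of each other. The nitro and the further methoxy therefore count here only in combination on one ring, and the effect of either group depends on the other in these three compounds. No measurement is available that would explain this dependence.

From the compounds shown here alone, whether an amine or a nitrile at this place would follow the nitro stays open. So does whether the combination holds with the nitro ortho to a methoxy group on any other core.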